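A Carboxy Replacement at a Position That Has Shown Nothing

The source may hold more compounds than are shown below. What is called first, only, known or untested is meant among the compounds shown, and "the series" means these compounds.

Compound 2 `O=c1cc(Nc2ccccc2)c2ccc(OCc3cccc(Cl)c3)cc2o1` gives 0% in an assay on isolated protein (strain Sprague-Dawley) for inhibition of Amine oxidase [flavin-containing] A (Rattus norvegicus), read by spectrophotometry, with a stated time of 5 min, tested at 10 uM; a lower number here means less inhibition, a higher number more inhibition at the concentration tested (going by the name of the read-out). Its nearest neighbour, compound 1 `O=C(O)COc1cc(=O)oc2cc(OCc3cccc(Cl)c3)ccc12`, gives 0% in this assay, and the step of no change at the digits printed from compound 1 to compound 2 (within the scatter), anilino in place of carboxymethoxy on an aromatic carbon, left the read-out unchanged within the scatter. Compound 3 `O=C(O)c1cc(=O)oc2cc(OCc3cccc(Cl)c3)ccc12` has not yet been measured in this assay; it differs from compound 2 as follows: carboxy in place of anilino on an aromatic carbon. For the measured compounds named here, only that single step bears on this position, and it was flat, so a further exchange of the group at the same place gives no reason to expect a move beyond the scatter in either direction. Compound 3 is therefore expected to give 0%, within 0% to 10%, which amounts to an expected step of no change at the digits printed from compound 2 to compound 3 (within the scatter).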

Compound 3, a percentage reported as inhibition, at one concentration (the size of the read-out at that concentration, not a potency): 0%
Compound 3: middle estimate and measured number agree at the digits printed; the range from low to high includes it.
By their numbers in this assay, from the lowest: compounds 1, 2 and 3 (each within the scatter of the next).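

In this assay, carboxy in place of anilino gave no change at the digits printed from compound 2 to compound 3 (within the scatter) so a group with no ring on this aromatic carbon reads the same as one carrying a six-membered aromatic ring. Carboxy in place of carboxymethoxy gave no change at the digits printed from compound 1 to compound 3 (within the scatter) so the acid attached directly and the carboxymethoxy group cannot be told apart here, and compound 3 at 0% adds a third group to a set that shows no inhibition at this position. Nothing measured here accounts for this flat reading.

On these data alone, whether any group at this position can produce inhibition remains open, as three different groups have given one and the same reading. As far as these compounds go, a methyl group, an amine or a longer chain ending in a carboxylic acid would extend the test, and the part of the core shared by all three compounds remains unexplored.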